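The source may report more compounds than this note shows. Statements on the series, on what has been measured and on what is new or still open speak of the compounds shown alone.

Working notes on the series. Within the data shown here, only two compounds have been measured so far in a functional assay on CCRF-CEM cells (Homo sapiens) for inhibition; on this read-out higher numbers stand for weaker inhibition and lower numbers for stronger inhibition. Compound 1 `COc1cc(NC(=O)Nc2cccc(C)c2)ccc1-c1cnco1` gives 1000 nM. Compound 2 `Cn1cc(C#N)c2ccc(Nc3ncc(-c4ccccc4)o3)cc21` gives 8000 nM, the higher of the two numbers and therefore the weaker inhibition of the pair, with a gap to compound 1 that lies beyond the scatter.

Compound 3 `Cc1cccc(-c2cnc(Nc3ccc4c(C#N)cn(C)c4c3)o2)c1` is still unmeasured in this assay. Its structure departs from compound 2 in one place: methyl in place of hydrogen on an aromatic carbon. Seen one bond further out, the change turns phenyl into 3-methylphenyl, with the new group meta to a large group.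

Among the measured compounds shown here, no pair of measured compounds differs in one place, so the series offers no direct precedent for this change, and the expectation below is loose. A small shift toward stronger inhibition seems the likeliest outcome, though a result within the scatter of compound 2 would be no surprise. The expected size is a 2.0-fold lower number from compound 2 to compound 3 (0.30 log units; within the scatter) in this assay. Compound 3 is estimated at 4000 nM, with an expected range of 1200 nM to 12000 nM.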

Compound 3, half-maximal inhibitory concentration: > 10000 nM
Compound 3 ended at the assay's limit (the forecaster's own chance of this, stated with the estimate: 10%); middle value at least 2.5-fold (0.39 log units) away from the limit.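

Compound 3 reads > 10000 nM in this assay, which is a limit of the assay and not a number. For methyl in place of hydrogen on an aromatic carbon, turning phenyl into 3-methylphenyl, the series now has its first single-place step: an at least 1.2-fold higher number from compound 2 to compound 3 (0.09 log units; that floor lies within the scatter), so this position shows no gain in inhibition from the added methyl, although the floor of the step does not establish a real loss. The true size of the step cannot be read, because the value of compound 3 stands at the limit: the limit of > 10000 nM in this assay, at which 1 of the 3 values shown sits.

As far as these compounds go, whether an amine, a carboxylic acid, a methoxy group or a longer chain in the same place on the phenyl would read any differently from methyl in this assay stays open, as does whether hydrogen is the better choice here or the two simply cannot be told apart. Compound 1 differs from compound 2 and compound 3 in more than one place, so it gives no reading on this change, and the compounds shown carry no second example of it on another core.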